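Benzyl to Nitropyridinyl on a Sulfur Linker

The source may report more compounds than this note shows. Statements on the series, on what has been measured and on what is new or still open speak of the compounds shown alone.

Within the data shown here, compound 2 `Cc1ccc(-c2nc(SCc3ccccc3)c3cc(Cl)ccc3n2)cc1` gives 11.3 ug/mL in a functional assay on HeLa cells (Homo sapiens) for antiproliferative activity, read by MTT assay, with a stated time of 48 h (on this read-out lower numbers stand for stronger inhibition and higher numbers for weaker inhibition), the lower of the two numbers measured so far, though only within the scatter of compound 1. Compound 1 `Cc1ccc(-c2nc(NC(=O)c3ccccc3)c3cc(Cl)ccc3n2)cc1` in this assay gives 16.2 ug/mL, and the step of a 1.4-fold lower number from compound 1 to compound 2 (0.16 log units; within the scatter) is within the scatter. Compound 3 `Cc1ccc(-c2nc(Sc3ncccc3[N+](=O)[O-])c3cc(Cl)ccc3n2)cc1` is not yet measured. It differs from compound 2 by 3-nitropyridin-2-yl in place of benzyl on a sulfur. Among the measured compounds shown here, the single measured step alters the same place in a different way and stays within the scatter, so no step beyond the scatter is expected here. Compound 3 is therefore estimated at 9 ug/mL, between 4 ug/mL and 25 ug/mL, a step of a 1.3-fold lower number from compound 2 to compound 3 (0.10 log units; within the scatter).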

Compound 3, half-maximal inhibitory concentration: 5.39 ug/mL
For compound 3 the middle estimate is 1.7-fold (0.22 log units) above the measured one, within the range that was stated.
By their numbers in this assay, from the lowest: compound 3; then compounds 2 and 1 (each within the scatter of the next).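

In this assay, among these compounds, the exchange of benzyl for 3-nitropyridin-2-yl on the sulfur gives a 2.1-fold lower number from compound 2 to compound 3 (0.32 log units; beyond the scatter) and is the first step here beyond the scatter, though a modest one. The group carried on this sulfur can therefore shift the number, which the earlier benzamido to benzylsulfanyl exchange did not show. Nothing measured here accounts for the shift.

As far as these compounds go, the change replaces the carbon ring and adds a nitro group at once, so the contribution of each stays open. A plain pyridin-2-yl or a 2-nitrophenyl on the sulfur would separate the two.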